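This account rests on a few compounds, and the source may have more. Where it says the series, first, only, none or still open, it means among the compounds named here.

The series shares one core; compound 1 `Cc1cn(C2CCN(Cc3cccc(Oc4cccc(OC(F)(F)F)c4)c3)CC2)c(=O)[nH]c1=O` carries 3-(trifluoromethoxy)phenyl on the oxygen on the aromatic ring, compound 3 `Cc1cn(C2CCN(Cc3cccc(Oc4ccc(F)c(F)c4)c3)CC2)c(=O)[nH]c1=O` carries 3,4-difluorophenyl there, and compound 2 `Cc1cn(C2CCN(Cc3cccc(Oc4ccncc4)c3)CC2)c(=O)[nH]c1=O` carries another group at that position. In an ADME assay on MRC5 cells (Homo sapiens) for cytotoxicity, read by fluorescence and resazurin assay, with a stated time of 3 days (a higher number here means a weaker inhibitor, a lower number a stronger inhibitor), compound 1 gives 5260 nM. For compound 2 the result is "not determined" (no result reported). Compound 3 reaches only the limit of this assay, > 64000 nM, which is a limit and not a number. Compound 3 therefore stands at the high end of the numbers shown, holding a limit, with one further entry in the series that has no number at all. Among the compounds with values here, the single step, an at least 12-fold higher number from compound 1 to compound 3 (1.08 log units; beyond the scatter), is at least as large as stated because compound 3 sits at the limit of > 64000 nM in this assay, at which 1 of the 3 values shown sits.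

Compound 4 `Cc1cn(C2CCN(Cc3cccc(Oc4cc(Cl)cc(Cl)c4)c3)CC2)c(=O)[nH]c1=O` differs from compound 3 at the same place: 3,5-dichlorophenyl in place of 3,4-difluorophenyl on an oxygen on an aromatic ring. Within the data shown here, the only measured step bears on this position and shows that exchanging the aryl group there can move the number beyond the scatter, but it is anchored at a limit, so its true size is open. Since compound 3 already sits at the limit, compound 4 is expected to stay near it, with the step of an at least 1.6-fold lower number from compound 3 to compound 4 (0.20 log units; that floor lies within the scatter) expected to fall within the scatter. The value of compound 4 is estimated at 40000 nM, between 8000 nM and 100000 nM, with a fair chance that this assay again reports only a limit.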

Compound 4, half-maximal inhibitory concentration: 6730 nM
Estimate against measurement, compound 4: 5.9-fold (0.77 log units) above, outside the stated range (below it).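

In this assay, the high reading of compound 3 does not extend to every halogen-bearing phenyl group on this oxygen: 3,5-dichlorophenyl in place of 3,4-difluorophenyl gives an at least 9.5-fold lower number from compound 3 to compound 4 (0.97 log units; beyond the scatter) and brings the number back into the range of measured values. The size of this step is only a floor because the reading of compound 3 is a limit and not a number: (the limit of > 64000 nM in this assay, at which 1 of the 4 values shown sits). Within the data shown here, exchanging 3-(trifluoromethoxy)phenyl for 3,5-dichlorophenyl gives a 1.3-fold higher number from compound 1 to compound 4 (0.11 log units; within the scatter) and so no real separation, which leaves 3,4-difluorophenyl as the only group here that stands apart from both others.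

Still open, from the compounds shown here alone, is how far compound 3 truly lies from the other two, and whether the separation follows the kind of halogen or its place on the ring, as 3,4-difluorophenyl and 3,5-dichlorophenyl differ in both. Going by these compounds, a 3,5-difluorophenyl group on this oxygen would separate those two factors, and the reading for a phenyl ring carrying an amine or a carboxylic acid also remains unknown.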